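Swapping an amide for a hydroxyl on the cyclohexyl ring

The compounds below may be only part of what the source reports. "The series", "measured", "known", "first", "only" and "open" are said of these compounds alone.

Measured so far:
- Compound 1 `N#Cc1cnc(NCc2cnccc2C(F)(F)F)cc1N[C@H]1C[C@@H](O)C1` gives 500 nM in an assay on isolated protein for inhibition of protein kinase C theta type (Homo sapiens), read by TR-FRET, with a stated time of 2 h; a lower number here means a stronger inhibitor, a higher number a weaker inhibitor.
- Compound 2 `N#Cc1cnc(NCc2cnccc2C(F)(F)F)cc1N[C@H]1C[C@H](O)C1` gives 900 nM in this assay.
- Compound 3 `CNC(=O)[C@H]1CC[C@@H](Nc2cc(NCc3cnccc3C(F)(F)F)ncc2C#N)CC1` gives 27 nM in this assay.

Compound 3 has the lowest number of the three, and its steps to both others are beyond the scatter: a 19-fold lower number from compound 1 to compound 3 (1.27 log units; beyond the scatter) and a 33-fold lower number from compound 2 to compound 3 (1.52 log units; beyond the scatter). Compounds 1 and 2 differ only in configuration as drawn (the fact that compounds 1 and 2 differ only in the configuration as drawn), and their numbers sit within the scatter of each other: a 1.8-fold higher number from compound 1 to compound 2 (0.26 log units; within the scatter).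

Compound 4 `CC1(C)C[C@H](Nc2cc(NCc3cnccc3C(F)(F)F)ncc2C#N)CC[C@H]1O` is not yet measured. It differs from compound 3 in one place: 4-hydroxy-3,3-dimethylcyclohexyl in place of 4-(methylcarbamoyl)cyclohexyl on a nitrogen on an aromatic ring. Among the measured compounds shown here, no measured step changes only this part of the molecule; the nearest evidence is the large gain seen when the 3-hydroxycyclobutyl of compounds 1 and 2 was replaced by the six-membered ring of compound 3. Compound 4 keeps a six-membered ring but returns to a hydroxyl, so a modest loss relative to compound 3 is expected, smaller than those steps. Compound 4 is therefore expected to give about 60 nM in this assay, within 15 nM to 250 nM, a step of a 2.2-fold higher number from compound 3 to compound 4 (0.35 log units; beyond the scatter) that is expected to be near the edge of the scatter.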

Compound 4, half-maximal inhibitory concentration: 100 nM
For compound 4 the middle estimate is 1.7-fold (0.22 log units) below the measured one, within the range that was stated.
By their numbers in this assay, from the lowest: compound 3; then compound 4; then compounds 1 and 2 (each within the scatter of the next).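

In this assay a hydroxyl on a six-membered ring does clearly better than a hydroxyl on the smaller ring, with a 9.0-fold lower number from compound 2 to compound 4 (0.95 log units; beyond the scatter) and a 5.0-fold lower number from compound 1 to compound 4 (0.70 log units; beyond the scatter) from the two mirror-image cyclobutyl compounds. Part of the large gain seen with compound 3 therefore survives without the methylcarbamoyl group, although compound 4 also brings two added methyl groups. Even so, a 3.7-fold higher number from compound 3 to compound 4 (0.57 log units; beyond the scatter) shows that the 4-(methylcarbamoyl)cyclohexyl stays ahead of the 4-hydroxy-3,3-dimethylcyclohexyl.

Nothing established here explains that remaining difference. The compounds shown also leave open how much of it belongs to the hydroxyl and how much to the two methyl groups, and how a carboxylic acid or an amine on the cyclohexyl ring would compare.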